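Three aryl oxobutenoic acids and a fourth, to be measured

The source may report more compounds than this note shows. Statements on the series, on what has been measured and on what is new or still open speak of the compounds shown alone.

Measured so far:
compound 1, `Cc1cc(C2CCCCC2)c(C)cc1C(=O)/C=C/C(=O)O`: 2380 nM
compound 2, `CCc1ccc(C(=O)/C=C/C(=O)O)cc1`: 27800 nM
compound 3, `CCc1ccc(C(C)C)cc1C(=O)/C=C/C(=O)O`: 4890 nM

All three share the same oxobutenoic acid side chain on an aromatic core and differ only in what the core carries. In a functional assay on HeLa cells (Homo sapiens) for inhibition, read by MTT assay, with a stated time of 72 h (a lower number here means a stronger inhibitor, a higher number a weaker inhibitor), compound 2 has the highest number of the three; its nearest neighbour is compound 3, whose number lies well below it, beyond the scatter, and compound 1 lies further still. Compound 2 thus carries the plainest substitution pattern and the weakest result of the set.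

Compound 4, `CC(C)c1ccc(C(=O)/C=C/C(=O)O)cc1`, is the next analogue and has not yet been measured in this assay. Its difference from compound 2 is methyl in place of hydrogen on a saturated chain carbon bound to an aromatic carbon and a saturated chain carbon, which, read one bond further out, is the change from ethyl to isopropyl. Among the compounds with values here, no step between two measured compounds isolates this change. Compound 3 also bears an isopropyl group and gives 4890 nM, whereas compound 2 gives 27800 nM, but compound 3 differs from compound 2 in more than one place, so only the bare comparison can be drawn.

The step from compound 2 to compound 4 is expected to be small and toward a lower number, a 1.9-fold lower number from compound 2 to compound 4 (0.27 log units; within the scatter), possibly within the scatter. Compound 4 is estimated at 15000 nM in this assay, with a range from 6000 nM to 40000 nM.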

Compound 4, half-maximal inhibitory concentration: 4900 nM
Compound 4: the middle estimate sits 3.1-fold (0.49 log units) above what was measured, outside the stated range (below it).
By their numbers in this assay, from the lowest: compound 1; then compounds 3 and 4 (each within the scatter of the next); then compound 2.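

In this assay, within the data shown here, the change from ethyl to isopropyl gives a 5.7-fold lower number from compound 2 to compound 4 (0.75 log units; beyond the scatter), so this single methyl in place of hydrogen, on a saturated chain carbon bound to an aromatic carbon and a saturated chain carbon, is enough on its own to move the number beyond the scatter, a change that no earlier pair could isolate. Compound 4 gives 4900 nM and compound 3, which also bears an isopropyl group, gives 4890 nM, two values within the scatter of each other. Nothing available accounts for the size of this step.

Open, as far as these compounds go, is whether the trend on this chain carries on to tert-butyl or to a longer chain such as propyl, or whether a hydroxyl group or an amine on the same carbon would keep the number of compound 4. With only this one cell assay shown, it is also open whether the step from ethyl to isopropyl would hold in another cell line or reflects inhibition of any particular target.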